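Fluoro on the outer phenyl ring of compound 2

The source may hold more compounds than are shown below. What is called first, only, known or untested is meant among the compounds shown, and "the series" means these compounds.

Of the compounds shown here, two share one core and have been measured in a functional assay on A549 cells (Homo sapiens) for cytotoxicity, read by MTT assay, with a stated time of 72 h; a higher number here means a weaker inhibitor, a lower number a stronger inhibitor. Compound 1 `COc1cc2c(Oc3ccc(NC(=O)c4cn(-c5ccccc5)nn4)cc3F)ccnc2cc1OCCCN1CCCCC1` gives 130 nM in this assay. Compound 2 `COc1cc2c(Oc3ccc(NC(=O)c4cn(-c5ccccc5)nn4)cc3F)ccnc2cc1OCCCN1CCC(C)CC1` gives 140 nM in this assay, the higher of the two numbers, though the step of a 1.1-fold higher number from compound 1 to compound 2 (0.03 log units; within the scatter) is within the scatter, so the two compounds cannot be ordered on these numbers.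

Compound 3 `COc1cc2c(Oc3ccc(NC(=O)c4cn(-c5ccccc5F)nn4)cc3F)ccnc2cc1OCCCN1CCC(C)CC1` differs from compound 2 by one change: fluoro in place of hydrogen on an aromatic carbon. Among the compounds with values here, only one measured step exists, that from compound 1 to compound 2, and it concerns a methyl on a saturated ring at the other end of the molecule; no measured step touches the phenyl on the triazole. Within the data shown here, the one step at hand was small, and there is no measured precedent for the change toward compound 3, so no step beyond the scatter is expected in this assay. The expected step from compound 2 to compound 3 is no change at the digits printed from compound 2 to compound 3 (within the scatter). Compound 3 is therefore estimated at 140 nM in this assay, with a range from 60 nM to 330 nM.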

Compound 3, half-maximal inhibitory concentration: 250 nM
Compound 3: the middle estimate sits 1.8-fold (0.25 log units) below what was measured; the range from low to high includes it.
By their numbers in this assay, from the lowest: compounds 1, 2 and 3 (each within the scatter of the next).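

In this assay, the phenyl on the triazole now has its first measured step: the change from phenyl to 2-fluorophenyl gives a 1.8-fold higher number from compound 2 to compound 3 (0.25 log units; within the scatter), so fluoro in place of hydrogen, ortho to a large group, shifts the number by no more than the scatter at this position. This end of the molecule thus joins the saturated ring at the other end, where methyl in place of hydrogen gave a 1.1-fold higher number from compound 1 to compound 2 (0.03 log units; within the scatter), and each of the two single changes shown stays within the scatter. No measurement bears on what lies behind the step at the phenyl, so the result stands here as a number alone.

The compounds shown leave open whether this position stays as undemanding with a larger or differently built group, such as a methoxy, a trifluoromethyl, an amine or a carboxylic acid, in place of the fluoro. They also leave open what fluoro does elsewhere on the same phenyl ring, and whether any of these readings would hold outside this assay in another kind of test.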